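Removing Both Chlorines From the Anilide of Compound 1

The source may hold more compounds than are shown below. What is called first, only, known or untested is meant among the compounds shown, and "the series" means these compounds.

The measured compounds in a functional assay on Molt4/C8 cells (Homo sapiens) for cytotoxicity; a higher number here means a weaker inhibitor, a lower number a stronger inhibitor:
Compound 1, `O=C(/C=C/C(=O)N1C/C(=C\c2ccccc2)C(=O)/C(=C/c2ccccc2)C1)Nc1ccc(Cl)c(Cl)c1`: 1700 nM
Compound 2, `O=C(/C=C/C(=O)N1C/C(=C\c2ccc([N+](=O)[O-])cc2)C(=O)/C(=C/c2ccc([N+](=O)[O-])cc2)C1)Nc1ccc(Cl)cc1`: 1200 nM
Compound 3, `Cc1cccc(C)c1NC(=O)/C=C/C(=O)N1C/C(=C\c2ccc([N+](=O)[O-])cc2)C(=O)/C(=C/c2ccc([N+](=O)[O-])cc2)C1`: 210 nM

Compound 1 gives the highest of the three numbers in this assay. Compound 2 sits within the scatter of it, so the two cannot be put in order; compound 3 lies beyond the scatter, well below compound 1.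

Compound 4, `O=C(/C=C/C(=O)N1C/C(=C\c2ccccc2)C(=O)/C(=C/c2ccccc2)C1)Nc1ccccc1`, is not yet measured. It differs from compound 1 in one place: phenyl in place of 3,4-dichlorophenyl on an amide-type nitrogen. The shared core and the unsubstituted benzylidene groups of compound 1 stay as they are.

Among the measured compounds shown here, only one measured step touches the aryl group on the amide-type nitrogen: a 5.7-fold lower number from compound 2 to compound 3 (0.76 log units; beyond the scatter). That step exchanged one substituted aryl for another on a core carrying nitrophenyl groups, so it does not tell directly what removing both chlorines from compound 1 will do. For the measured compounds named here, no pair among the measured compounds separates a chlorinated anilide from a bare one. The expectation for compound 4 therefore rests on the step from compound 1 being small, in no definite direction, or none beyond the scatter; the estimate is a 1.1-fold lower number from compound 1 to compound 4 (0.05 log units; within the scatter).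

For compound 4 this assay is expected to give about 1500 nM, between 500 nM and 4500 nM.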

Compound 4, half-maximal inhibitory concentration: 520 nM
Compound 4: middle estimate off by 2.9-fold (0.46 log units), on the high side, and the stated range covers the measured number.
By their numbers in this assay, from the lowest: compound 3; then compound 4; then compounds 2 and 1 (each within the scatter of the next).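

Among the compounds shown here, the step of a 3.3-fold lower number from compound 1 to compound 4 (0.51 log units; beyond the scatter) in this assay is the first measured change at this position that separates a chlorinated anilide from a bare one, and it shows that the 3,4-dichlorophenyl group of compound 1 can give way to phenyl with a lower number as the result. For the compounds shown here, the only earlier step on this amide-type nitrogen, a 5.7-fold lower number from compound 2 to compound 3 (0.76 log units; beyond the scatter) on a core carrying nitrophenyl groups, exchanged one substituted aryl for another, so it could not show what losing the chlorines alone does with the unsubstituted benzylidene groups in place. Both steps at this position now lie beyond the scatter, on two different cores and with different aryl groups, so this nitrogen's aryl group matters in each of these two pairs, while no evidence bears on the reason for the change.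

The compounds shown leave open whether one chlorine alone would account for the step from compound 1, and whether 2,6-dimethylphenyl would also give a lower number on the core of compound 4. They also leave open how a methoxy group or an amine on the anilide's phenyl ring would compare with the bare phenyl of compound 4.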